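This account rests on a few compounds, and the source may have more. Where it says the series, first, only, none or still open, it means among the compounds named here.

Going by the values given here, compound 2 `CCCCCCCCCCSc1nnc(Cc2nn(C)c(=O)c3ccccc23)n1C` gives 7600 nM in an assay on isolated protein (Mus musculus) for inhibition of IL15-IL15 receptor (Homo sapiens), read by resazurin assay, with stated times of 30 min and 2.5 days (a lower number here means a stronger inhibitor, a higher number a weaker inhibitor), and stands as the higher of the two numbers measured so far; its nearest neighbour is compound 1 `Cn1c(Cc2nn(C)c(=O)c3ccccc23)nnc1SCCCCCCCC(=O)Nc1ccc(Cl)cc1Cl`, which gives 1900 nM. Compound 3 `Cn1c(Cc2nn(C)c(=O)c3ccccc23)nnc1SCCCCCCCC(=O)Nc1ccc(Cl)cc1` has not yet been measured; it differs from compound 2 by (4-chlorophenyl)carbamoyl in place of propyl on a saturated chain carbon, seven bonds along the chain from a sulfur. Among the compounds with values here, the only measured step that bears on this change is a 4.0-fold higher number from compound 1 to compound 2 (0.60 log units; beyond the scatter), which runs the opposite way, exchanging a related carbamoyl group for propyl. Reversing that step, compound 3 is expected to give a lower number than compound 2, a step of about a 3.8-fold lower number from compound 2 to compound 3 (0.58 log units; beyond the scatter). The estimate for compound 3 is therefore 2000 nM, with a range from 800 nM to 5000 nM.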

Compound 3, half-maximal inhibitory concentration: 800 nM
The estimate for compound 3 lay 2.5-fold (0.40 log units) above the measured number; the measured number falls inside the stated range.
By their numbers in this assay, from the lowest: compound 3; then compound 1; then compound 2.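

Putting the (4-chlorophenyl)carbamoyl group in place of propyl at this chain end gives a larger change (a 9.5-fold lower number from compound 2 to compound 3 (0.98 log units; beyond the scatter)) than the earlier pair showed. The second chloro is not needed for this gain: hydrogen in its place on the aromatic carbon gives a further change (a 2.4-fold lower number from compound 1 to compound 3 (0.38 log units; beyond the scatter)). Nothing measured here explains either change. Still open, from the compounds shown here alone, is whether the ring or the carbamoyl link matters more, and whether a carboxylic acid or an amine at the chain end would serve as well.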